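Bromo for Acetyl on the Phenyl Ether

The source may hold more compounds than are shown below. What is called first, only, known or untested is meant among the compounds shown, and "the series" means these compounds.

This account follows three compounds that share a core and are measured in an assay on microsomes from liver for inhibition of acyl-CoA desaturase 1 (Rattus norvegicus); on this read-out lower numbers stand for stronger inhibition and higher numbers for weaker inhibition. Compound 1 `Cc1nnc(-c2ccc(N3CCC(Oc4ccccc4C(F)(F)F)CC3)nn2)s1` gives 2.3 nM. Compound 2 `CC(=O)c1ccccc1OC1CCN(c2ccc(-n3ccnc3)nn2)CC1` gives 34 nM, and compound 3 `Cc1cccc(OC2CCN(c3ccc(-n4ccnc4)nn3)CC2)c1` gives 251 nM. Compound 2 thus stands second highest of the three numbers: compound 3 sits nearest, and compound 1 lies furthest away with a lower number.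

Compound 4 `Brc1ccccc1OC1CCN(c2ccc(-n3ccnc3)nn2)CC1` differs from compound 2 in one place: bromo in place of acetyl on an aromatic carbon. For the measured compounds named here, the only step measured at this position is a 7.4-fold higher number from compound 2 to compound 3 (0.87 log units; beyond the scatter), where the 2-acetylphenyl was exchanged for 3-methylphenyl. Compound 1 carries a 2-trifluoromethylphenyl on the same oxygen but also a different ring on the other end of the core, so its value shows only that a 2-substituted phenyl ether can reach a low number. Because the change in compound 3 gave a 7.4-fold higher number from compound 2 to compound 3 (0.87 log units; beyond the scatter), a weakening step is expected for compound 4 as well, though smaller, so compound 4 is estimated at 60 nM with a range from 15 nM to 250 nM, which is a step of a 1.8-fold higher number from compound 2 to compound 4 (0.25 log units; within the scatter).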

Compound 4, half-maximal inhibitory concentration: 5 nM
The estimate for compound 4 lay 12-fold (1.08 log units) above the measured number; measured number outside the range, below it.
By their numbers in this assay, from the lowest: compound 1; then compound 4; then compound 2; then compound 3.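

In this assay, for the compounds shown here, the exchange of acetyl for bromo brings a 6.8-fold lower number from compound 2 to compound 4 (0.83 log units; beyond the scatter) and is the first step at this position to go toward stronger inhibition, so the hydrogen-bond acceptor of the acetyl is not needed for a low number here. The step of a 50-fold lower number from compound 3 to compound 4 (1.70 log units; beyond the scatter) is larger, but it changes both the group and its place on the phenyl ring, and the two contributions cannot be separated from these compounds. No measurement at hand bears on the reason for either step.

Going by these compounds, it remains open whether chloro, methoxy or an amine in place of the bromo would give a lower or a higher number. Also open, on these data alone, is how much of the larger step comes from the place of the group alone, and whether bromo would act alike on the core of compound 1.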